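Shifting a hydroxyl group along a saturated acid chain

The source may report more compounds than this note shows. Statements on the series, on what has been measured and on what is new or still open speak of the compounds shown alone.

Compound 2 `CCC(O)CCCCCCCCC(=O)O` stands at the edge of what a functional assay on CHO cells for agonist activity at G-protein coupled receptor 84 (Homo sapiens), read by scintillation counting and GTPgammaS binding, with a stated time of 1 h (a higher number here means that more compound is needed for the effect, a lower number that less compound is needed), can report: in this assay compound 2 gives > 100000 nM, which is a limit of the assay and not a number. Compound 1 `CCCC(O)CCCCCCCC(=O)O` gives > 100000 nM in this assay, also a limit. The step that the two limits leave unreadable from compound 1 to compound 2 is therefore unreadable, as the limit of > 100000 nM in this assay, at which 2 of the 2 values shown sit, records. Compound 3 `CC(O)CCCCCCCCCC(=O)O` differs from compound 2 by 2-hydroxypropyl in place of 1-hydroxypropyl on a saturated chain carbon, eight bonds along the chain from a carbonyl carbon. Among the compounds with values here, only one measured step bears on this change, the one that runs from compound 1 to compound 2, and its size cannot be read, because both ends are limits; two limits give no direction either. One therefore expects for compound 3 a step of a number no higher from compound 2 to compound 3 (the limit leaves the size open) of no readable size. Compound 3 is estimated at 100000 nM in this assay, with a range from 30000 nM to 300000 nM, and most likely reported again as a limit.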

Compound 3, half-maximal effective concentration: > 100000 nM
Compound 3: a limit, no number; the forecaster's own chance of this, stated with the estimate: 85%; the middle value lies on the limit itself.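

No step among compound 1, compound 2 and compound 3 can be read, for each result is a limit and not a number: the limit of > 100000 nM in this assay, at which 3 of the 3 values shown sit.

The compounds shown leave open whether moving the hydroxyl group along this chain changes the response in this assay at all.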